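Thiomethyl Substituent Swap on a Shared Core, Cell Growth Read-out

The source may hold more compounds than are shown below. What is called first, only, known or untested is meant among the compounds shown, and "the series" means these compounds.

Working notes on the series. In a functional assay on HGC-27 cells (Homo sapiens) for inhibition, read by MTT assay, with a stated time of 72 h (on this read-out lower numbers stand for stronger inhibition and higher numbers for weaker inhibition), compound 1 `Cc1cc(N2CC[C@@H](C)[C@@H](N(C)c3ncnc4[nH]ccc34)C2)n2nc(SCc3nc4ccccc4[nH]3)nc2n1` gives > 100000 nM, which is a limit of the assay and not a number. Compound 2 `C[C@@H]1CCN(c2cc(-c3ccccc3)nc3ncnn23)C[C@@H]1N(C)c1ncnc2[nH]ccc12`, a relative with a different substituent pattern on the shared core, likewise sits at a limit in this assay, giving > 100000 nM. So compound 1 stands nowhere distinct on the numbers shown: both values on hand are limits, and there is no measured step between compounds that differ in one place.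

Compound 3 `Cc1cc(N2CC[C@@H](C)[C@@H](N(C)c3ncnc4[nH]ccc34)C2)n2nc(SCc3cc(Cl)ccc3Cl)nc2n1` is the next entry to be measured. It differs from compound 1 by 2,5-dichlorophenyl in place of 1H-benzimidazol-2-yl on a saturated chain carbon bound to a sulfur.

Going by the values given here, no step is on hand to anchor this change. Because (the limit of > 100000 nM in this assay, at which 2 of the 2 values shown sit), the expectation is that the step from compound 1 to compound 3 falls within the scatter, with no direction beyond it; the expected step is an at least 1.2-fold lower number from compound 1 to compound 3 (0.09 log units; that floor lies within the scatter). Compound 3 is therefore estimated at 80000 nM, in the range 20000 nM to 300000 nM, with a fair chance that this assay again reports only a limit.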

Compound 3, half-maximal inhibitory concentration: 19200 nM
The estimate for compound 3 lay 4.2-fold (0.62 log units) above the measured number; the measured number lies below the stated range.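

In this assay, this place on the saturated chain carbon bound to a sulfur proves able to move the read-out off the limit: 2,5-dichlorophenyl in place of 1H-benzimidazol-2-yl gives an at least 5.2-fold lower number from compound 1 to compound 3 (0.71 log units; beyond the scatter), the only step in the compounds shown and one that goes beyond the scatter. Compound 1 gives > 100000 nM, which is a limit and not a number. The step is therefore a floor, and its full size cannot be read, because of the following: the limit of > 100000 nM in this assay, at which 2 of the 3 values shown sit.

What the compounds shown leave open is which part of the change carries the step, as the swap replaces the whole 1H-benzimidazol-2-yl group with the 2,5-dichlorophenyl group, and a plain phenyl or a 4-chlorophenyl on the same chain carbon would separate the ring change from the chlorine atoms. Also open, going by these compounds, is how far this place tolerates other kinds of group, such as a carboxylic acid, an amine or a longer chain, and whether the same swap would act alike on a core carrying the substituent pattern of compound 2.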